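From methyl to nitro on the shared core

A few compounds are considered here, and "the series" means these few. Any claim that something is new, unique, unknown or untested is made for them only; others in the source may bear on it.

compound 1 `CC(C)(CCCCOc1cc(-c2ccc(Cl)cc2)c2ccccc2n1)C(=O)O`: 15 nM
compound 2 `Cc1ccc(-c2cc(OCCCCC(C)(C)C(=O)O)nc3ccccc23)cc1`: 30 nM

Both compounds were tested in an assay on membranes from spleen (Cavia porcellus) for binding affinity to leukotriene B4 receptor 1 (Homo sapiens); on this read-out higher numbers stand for weaker inhibition and lower numbers for stronger inhibition. Within the data shown here, compound 2 is one of only two compounds with a number here; its sole neighbour is compound 1, and the step of a 2.0-fold higher number from compound 1 to compound 2 (0.30 log units; within the scatter) falls within the scatter, so the two cannot be told apart on this read-out.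

Compound 3 `CC(C)(CCCCOc1cc(-c2ccc([N+](=O)[O-])cc2)c2ccccc2n1)C(=O)O` has not yet been measured. It differs from compound 2 in one place: nitro in place of methyl on an aromatic carbon.

Among the measured compounds shown here, one measured step bears on this position, a 2.0-fold higher number from compound 1 to compound 2 (0.30 log units; within the scatter), and it shows that swapping chloro for methyl on this aromatic carbon left the number within the scatter. For the measured compounds named here, no measured compound carries a nitro group there, so nothing measured speaks directly to this change. Going by the values given here, on the single step in hand, the expected step of a 1.2-fold higher number from compound 2 to compound 3 (0.07 log units; within the scatter) is none beyond the scatter, with a wide margin to allow for the unknown group.

Compound 3 is therefore estimated at 35 nM, with a range from 10 nM to 120 nM.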

Compound 3, half-maximal inhibitory concentration: 150 nM
Estimate against measurement, compound 3: 4.3-fold (0.63 log units) below; the whole stated range lies below it.
By their numbers in this assay, from the lowest: compounds 1 and 2 (each within the scatter of the next); then compound 3.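

In this assay, the aromatic carbon para to a large group proves sensitive to what it carries: nitro in place of methyl gives a 5.0-fold higher number from compound 2 to compound 3 (0.70 log units; beyond the scatter), and nitro in place of chloro gives a 10-fold higher number from compound 1 to compound 3 (1.00 log units; beyond the scatter). Chloro and methyl could not be told apart at this position, so the earlier pair gave no sign of such sensitivity, whereas the 4-nitrophenyl compound stands clearly apart from both. The three compounds therefore show that this position does not accept every group alike, though nothing in hand accounts for the step.

Among these compounds, with only three groups at this carbon, it remains open whether the weaker inhibition belongs to nitro alone or would also appear with an amine, a nitrile, a methoxy group or a carboxylic acid in the same place, and whether a bare hydrogen there would match chloro and methyl. On these data alone, all three compounds also share one chain ending in a carboxylic acid, so it is unknown whether the step from methyl to nitro would keep its size with a shorter or longer chain.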